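Chloro for Methoxy on the Aryl Imidazolone Chalcones

The source may report more compounds than this note shows. Statements on the series, on what has been measured and on what is new or still open speak of the compounds shown alone.

Compound 1: `COc1cc(/C=C/C(=O)c2cccc(-n3cc(-c4ccc(Cl)cc4)[nH]c3=O)c2)cc(OC)c1OC` — 1720 nM
Compound 2: `COc1ccc(-c2cn(-c3cccc(C(=O)/C=C/c4ccc(O)c(OC)c4)c3)c(=O)[nH]2)cc1` — 2440 nM
Compound 3: `COc1ccc(-c2cn(-c3cccc(C(=O)/C=C/c4cc(OC)c(OC)c(OC)c4)c3)c(=O)[nH]2)cc1` — 720 nM

Of the compounds shown here, three have been measured in a functional assay on LOX IMVI cells (Homo sapiens) for inhibition; a lower number here means a stronger inhibitor of growth, a higher number a weaker inhibitor of growth. Compound 3 gives 720 nM, while compound 1, which differs from it only by the change (chloro in place of methoxy on an aromatic carbon), gives 1720 nM; the step between them is a 2.4-fold higher number from compound 3 to compound 1 (0.38 log units; beyond the scatter). Compound 2 differs from compound 3 in the chalcone part, as described by 4-hydroxy-3-methoxyphenyl in place of 3,4,5-trimethoxyphenyl on a double-bonded chain carbon bound to a double-bonded chain carbon, and the step is a 3.4-fold lower number from compound 2 to compound 3 (0.53 log units; beyond the scatter). Compound 2 and compound 1 give values that lie within the scatter of one another, so no order between them is claimed.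

Compound 4, `COc1cc(/C=C/C(=O)c2cccc(-n3cc(-c4ccc(Cl)cc4)[nH]c3=O)c2)ccc1O`, has not yet been measured. It is related to compound 2 by chloro in place of methoxy on an aromatic carbon, which is the same change as that from compound 3 to compound 1, made on the same place in the ring, and occurring twice among these four compounds. For the measured compounds named here, the only guide to its size is the earlier step, so the account expects a step of about a 2.3-fold higher number from compound 2 to compound 4 (0.35 log units; beyond the scatter) from compound 2 to compound 4, resting on a 2.4-fold higher number from compound 3 to compound 1 (0.38 log units; beyond the scatter) and on the value of compound 2, 2440 nM. Since the core of compound 2 differs from that of compound 3 as given by 4-hydroxy-3-methoxyphenyl in place of 3,4,5-trimethoxyphenyl on a double-bonded chain carbon bound to a double-bonded chain carbon, the transfer of one step to another core is uncertain and the range is kept wide. The estimate for compound 4 in this assay is 5500 nM, expected to fall between 2500 nM and 12000 nM.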

Compound 4, concentration for 50% growth inhibition: 1630 nM
Compound 4: middle estimate off by 3.4-fold (0.53 log units), on the high side, and the stated range ends above it.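

On the core bearing the 4-hydroxy-3-methoxyphenyl group, the change from 4-methoxyphenyl to 4-chlorophenyl gives a 1.5-fold lower number from compound 2 to compound 4 (0.18 log units; within the scatter) in this assay and so sets no order between the two compounds, whereas on the core bearing the 3,4,5-trimethoxyphenyl group the same change gave a weaker inhibitor of growth. The change therefore does not carry over as a fixed step between these two cores, as the two steps set side by side show: the same change on two cores in this assay, a 2.4-fold higher number (0.38 log units; beyond the scatter) from compound 3 to compound 1 and a 1.5-fold lower number (0.18 log units; within the scatter) from compound 2 to compound 4, 3.6-fold (0.55 log units) apart, beyond the scatter of two such steps. For the compounds shown here, this comparison rests on only two matched pairs, so it does not show why the steps differ, how the change would behave on a third core, or whether either step is the more typical one for the series.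

The compounds shown leave open how other groups would behave at the same place on the six-membered aromatic ring of carbon only, such as fluoro, bromo, a methyl group, an amine or a carboxylic acid. They also leave open whether the difference between the two steps would recur with other chalcone aryl groups, such as a 4-hydroxyphenyl or a 3,4-dimethoxyphenyl group.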